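Pyridinyl for Imidazolyl on a Naphthol Lipoxygenase Inhibitor

The source may report more compounds than this note shows. Statements on the series, on what has been measured and on what is new or still open speak of the compounds shown alone.

Compound 1 `Cc1ccc2ccccc2c1O`: in an assay on RBL-1 cells with Polyunsaturated fatty acid 5-lipoxygenase (Rattus norvegicus) as the target (on this read-out lower numbers stand for stronger inhibition and higher numbers for weaker inhibition), compound 1 gives 130 nM.
Compound 2 `C=CCc1ccc2ccccc2c1O`: in this assay compound 2 gives 56 nM.
Compound 3 `Cn1ccnc1Cc1ccc2ccccc2c1O`: in this assay compound 3 gives 3500 nM.

Compound 3 stands at the highest number of the three. Going from compound 1 to compound 3 the number rose by a 27-fold higher number from compound 1 to compound 3 (1.43 log units; beyond the scatter), and going from compound 2 to compound 3 by a 63-fold higher number from compound 2 to compound 3 (1.80 log units; beyond the scatter); both steps put a heteroaryl group onto the saturated chain carbon bound to an aromatic carbon, and both lie beyond the scatter. Compound 4 `Oc1c(Cc2ccccn2)ccc2ccccc12` differs from compound 3 by pyridin-2-yl in place of 1-methyl-1H-imidazol-2-yl on a saturated chain carbon bound to an aromatic carbon. Among the compounds with values here, no measured step exchanges one heteroaryl group for another, so the two large steps into compound 3 are the only guide, and they suggest that a heteroaryl group at this place keeps the number high. A step of a 2.3-fold lower number from compound 3 to compound 4 (0.37 log units; beyond the scatter) is therefore expected, modest at most and toward a lower number. Compound 4 is estimated at 1500 nM in this assay, within a range from 400 nM to 6000 nM.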

Compound 4, half-maximal inhibitory concentration: 390 nM
Compound 4: middle estimate off by 3.8-fold (0.59 log units), on the high side; measured number outside the range, below it.
By their numbers in this assay, from the lowest: compound 2; then compound 1; then compound 4; then compound 3.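

Placed on a saturated chain carbon bound to an aromatic carbon, the two heteroaryl groups are not interchangeable in this assay: pyridin-2-yl in place of 1-methyl-1H-imidazol-2-yl gives (a 9.0-fold lower number from compound 3 to compound 4 (0.95 log units; beyond the scatter)), so the high number of compound 3 does not hold for every heteroaryl group at this place. Even so, pyridin-2-yl does not match vinyl (a 7.0-fold higher number from compound 2 to compound 4 (0.84 log units; beyond the scatter)) or hydrogen (a 3.0-fold higher number from compound 1 to compound 4 (0.48 log units; beyond the scatter)), and both heteroaryl compounds stay above the two compounds without such a group. Nothing at hand explains why the two heteroaryl groups differ.

The compounds shown leave open whether pyridin-3-yl, pyridin-4-yl or a plain phenyl group at this place would follow pyridin-2-yl. They also leave open how an amine or a carboxylic acid on a longer chain would compare with vinyl.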